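Series notes: changing the ring on the amine nitrogen

This account rests on a few compounds, and the source may have more. Where it says the series, first, only, none or still open, it means among the compounds named here.

Measured compounds:
compound 1 `Cc1nc(-c2ccccc2)c(C(=O)N2CCN(c3ccc(Cl)c(Cl)c3)CC2)o1` gives 124 nM
compound 2 `COc1cc(OC)cc(N2CCN(C(=O)c3oc(C)nc3-c3ccccc3)CC2)c1` gives 19.2 nM
compound 3 `COc1cccc(N2CCN(C(=O)c3oc(C)nc3-c3ccccc3)CC2)c1` gives 34.8 nM

All three share one core and differ only in the ring on the amine nitrogen. In a functional assay on HL-60 cells (Homo sapiens) for inhibition, read by MTT assay, with a stated time of 72 h (a lower number here means a stronger inhibitor, a higher number a weaker inhibitor), compound 3 stands second highest of the three numbers. Its nearest neighbour is compound 2: a 1.8-fold higher number from compound 2 to compound 3 (0.26 log units; within the scatter), so the two cannot be told apart. Its distance from compound 1 is real: a 3.6-fold lower number from compound 1 to compound 3 (0.55 log units; beyond the scatter).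

Compound 4 `Cc1nc(-c2ccccc2)c(C(=O)N2CCN(c3cc(Cl)cc(Cl)c3)CC2)o1` is the next step from compound 3: 3,5-dichlorophenyl in place of 3-methoxyphenyl on an amine nitrogen in a ring.

Within the data shown here, two measured steps bear on it. Both a 3.6-fold lower number from compound 1 to compound 3 (0.55 log units; beyond the scatter) and a 6.5-fold lower number from compound 1 to compound 2 (0.81 log units; beyond the scatter) run from a dichlorophenyl to a methoxyphenyl and both lower the number. Compound 4 reverses that direction, from a methoxyphenyl back to a dichlorophenyl, though its 3,5-dichlorophenyl is not the 3,4-dichlorophenyl of compound 1, so the comparison is only partial. The expectation is therefore a modest rise in this assay, a 2.2-fold higher number from compound 3 to compound 4 (0.33 log units; beyond the scatter), landing near compound 1 rather than beyond it.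

Compound 4 is estimated at 75 nM in this assay, with a range from 28 nM to 200 nM.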

Compound 4, half-maximal inhibitory concentration: 41.8 nM
Estimate against measurement, compound 4: 1.8-fold (0.25 log units) above, within the range that was stated.
By their numbers in this assay, from the lowest: compounds 2, 3 and 4 (each within the scatter of the next, the first and the last beyond it); then compound 1.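

Among these compounds, with 3,5-dichlorophenyl in place of 3,4-dichlorophenyl on the ring nitrogen, this assay gives a 3.0-fold lower number from compound 1 to compound 4 (0.47 log units; beyond the scatter) and so a dichlorophenyl at this position does not by itself set the number: the placing of the two chlorines matters here, which no earlier compound could show. Against the 3-methoxyphenyl, the exchange gives a 1.2-fold higher number from compound 3 to compound 4 (0.08 log units; within the scatter) and so cannot be read as a difference, whereas against the 3,5-dimethoxyphenyl it gives a 2.2-fold higher number from compound 2 to compound 4 (0.34 log units; beyond the scatter) and offers the only comparison here of chlorine with methoxy on a ring otherwise named alike. No measured evidence accounts for either result.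

The compounds shown leave open whether the same dependence on placing holds for methoxy, which a 3,4-dimethoxyphenyl would test against compound 1, and whether a single chlorine, as in a 3-chlorophenyl, would read differently from the 3-methoxyphenyl of compound 3. Rings of another kind on this nitrogen, such as a pyridyl, also remain open, as does any change to the shared core, which stays fixed across all four compounds.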